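The source may report more compounds than this note shows. Statements on the series, on what has been measured and on what is new or still open speak of the compounds shown alone.

In an assay on isolated protein for inhibition of Aromatase (Homo sapiens), read by fluorescence, using NADPH, with a stated time of 30 min, tested at 50 uM (a higher number here means more inhibition at the concentration tested (going by the name of the read-out), a lower number less inhibition), two compounds have been measured. Compound 1 `O=[N+]([O-])c1ccc2[nH]c(-c3cccnc3)cc2c1` gives 27.9% in this assay. Compound 2 `Cn1c(-c2ccccc2)cc2cc([N+](=O)[O-])ccc21` gives 77% in this assay, the higher of the two numbers; compound 1 lies below it by a gap that goes beyond the usual scatter. Going by the values given here, the two measured compounds differ in more than one place, so no single step between them can be read off.

Compound 3 `O=[N+]([O-])c1ccc2[nH]c(-c3ccccc3)cc2c1` has not yet been measured in this assay. It differs from compound 2 as follows: hydrogen in place of methyl on an aromatic nitrogen. Among the compounds with values here, the only other compound here with a hydrogen on that aromatic nitrogen is compound 1, whose value of 27.9% is the lower of the two, but compound 1 also carries a different group on the five-membered ring, so its number is only a loose pointer.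

On that basis the change is expected to lower inhibition in this assay, and the step of a number 27 percentage points lower from compound 2 to compound 3 (beyond the scatter) is estimated to reach beyond the scatter. Compound 3 is therefore expected to give about 50% in this assay, within a range from 25% to 75%.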

Compound 3, a percentage reported as inhibition, at one concentration (the size of the read-out at that concentration, not a potency): 77.7%
The estimate for compound 3 lay 27.7 percentage points below the measured number; measured number above the stated range.
By their numbers in this assay, from the lowest: compound 1; then compounds 2 and 3 (each within the scatter of the next).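

In this assay, on the aromatic nitrogen next to the ring atom bearing the phenyl group, the exchange of methyl for hydrogen gives a number 0.7 percentage points higher from compound 2 to compound 3 (within the scatter), so compound 2 and compound 3 stand level and, with phenyl in place, this position shows no dependence on which of the two it carries. The large difference between the measured compounds instead lies at the aromatic carbon, where phenyl in place of pyridin-3-yl gives a number 49.8 percentage points higher from compound 1 to compound 3 (beyond the scatter), a single change that could not be isolated from the first two compounds alone. The compounds shown offer no evidence on why either step has the size it has.

As far as these compounds go, it remains open whether the number stays level when the group on the aromatic nitrogen goes beyond a single methyl to an ethyl group, a longer chain or an acetyl group, and whether methyl in place of hydrogen would have the same small effect with pyridin-3-yl on the aromatic carbon. Also open, from the compounds shown here alone, is how the number would respond to an amine or a carboxylic acid on the phenyl ring, or to an amine in place of the nitro group.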